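The source may report more compounds than this note shows. Statements on the series, on what has been measured and on what is new or still open speak of the compounds shown alone.

Compound 1 `COc1ccccc1C(=O)NC(=O)Nc1ccc(-c2nccs2)c(C(F)(F)F)c1` is the less soluble of the two compounds measured here: in a physicochemical assay for solubility (a higher number here means a more soluble compound, a lower number a less soluble compound), compound 1 gives 1.1 ug/mL. Compound 2 `COc1ccncc1C(=O)NC(=O)Nc1ccc(-c2ccccc2)c(C(F)(F)F)c1`, which shares neither the same core substituent nor the same ring bearing the methoxy group, gives 17 ug/mL in this assay, a gap said to lie beyond the scatter. Compound 3 `COc1ccccc1C(=O)NC(=O)Nc1ccc(C(C)C)c(C(F)(F)F)c1`, not yet measured, differs from compound 1 only by isopropyl in place of 1,3-thiazol-2-yl on an aromatic carbon. For the measured compounds named here, no measured pair shows this change, so the step from compound 1 to compound 3 in this assay is expected to be small, perhaps upward, and possibly within the scatter; the estimate is a 1.8-fold higher number from compound 1 to compound 3 (0.26 log units; within the scatter). Compound 3 is therefore expected to give 2 ug/mL, within 0.5 ug/mL to 8 ug/mL.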

Compound 3, solubility: < 1 ug/mL
Compound 3 ended at the assay's limit; the forecaster's own chance of this, stated with the estimate: 10%; at least 2.0-fold (0.30 log units) between middle value and limit.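

In this assay compound 3 gives < 1 ug/mL, which is a limit of the assay and not a number. For the compounds shown here, the first direct reading of isopropyl in place of 1,3-thiazol-2-yl, on this aromatic carbon ortho to a trifluoromethyl group, is an at least 1.1-fold lower number from compound 1 to compound 3 (0.04 log units; that floor lies within the scatter), so the change shows no gain here. How large the step really is stays unread, since only its floor is known: the limit of < 1 ug/mL in this assay, at which 1 of the 3 values shown sits.

The compounds shown leave open whether an amine, a carboxylic acid or a longer chain at this position would give a value clear of the limit. They also leave open how the same change reads on the core of compound 2.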